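This account rests on a few compounds, and the source may have more. Where it says the series, first, only, none or still open, it means among the compounds named here.

Of the compounds shown here, two have been measured in a functional assay on Raji cells (Homo sapiens) (on this read-out higher numbers stand for weaker inhibition and lower numbers for stronger inhibition), so far. Compound 1 `C/C(=C\COc1ccc2ccc(=O)oc2c1)C1=CC(=N)C2(CCCCC2)O1` is the larger of the pair, and in this assay compound 1 gives 23.5 ug/mL. Compound 2 `O=C1C=C(c2ccccc2)OC1` is much smaller, and in this assay compound 2 gives 50.1 ug/mL, the higher of the two numbers; its gap to compound 1 lies beyond the usual scatter, so compound 2 is the weaker inhibitor of this pair. Compound 3 `COc1ccccc1C1=CC(=O)CO1` has not yet been measured. It differs from compound 2 in one place: methoxy in place of hydrogen on an aromatic carbon. Going by the values given here, no measured pair differs in this way, so nothing measured so far shows how a methoxy in place of hydrogen on an aromatic carbon shifts the read-out. For an exchange this small, the movement in this assay is expected to be modest and not clearly beyond the scatter, in either direction. The expected result for compound 3 is 40 ug/mL, with a range from 15 ug/mL to 110 ug/mL. This estimate means a 1.3-fold lower number from compound 2 to compound 3 (0.10 log units; within the scatter), a step expected to stay within the usual scatter.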

Compound 3, concentration for 50% inhibition: > 100 ug/mL
Compound 3 was reported as a limit; the forecaster's own chance of this, stated with the estimate: 15%; middle value at least 2.5-fold (0.39 log units) away from the limit.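

In this assay, compound 3 gives > 100 ug/mL, which is a limit of the assay and not a number. Going by these compounds alone, this is the first reading for a methoxy in place of hydrogen on an aromatic carbon, ortho to a group of 6 heavy atoms, and it shows an at least 1.9-fold higher number from compound 2 to compound 3 (0.30 log units; that floor lies within the scatter), with no gain in inhibition visible at this position. The floor of that step lies within the usual scatter, and the true size of the step cannot be read from a limit, which marks the end of what the read-out reports: the limit of > 100 ug/mL in this assay, at which 1 of the 3 values shown sits.

The compounds shown leave open whether this result belongs to methoxy itself or to its position on the ring. A hydroxyl or an amine at this same place could help separate the two, as could methoxy at another carbon of the ring.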